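Replacing 4-bromobenzyl with ethynyl on a sulfur

This account rests on a few compounds, and the source may have more. Where it says the series, first, only, none or still open, it means among the compounds named here.

- Compound 1 `Cc1cc(N2CC[C@@H](C)[C@@H](N(C)c3ncnc4[nH]ccc34)C2)n2nc(SCc3nc4ccccc4[nH]3)nc2n1`: 40200 nM
- Compound 2 `Cc1cc(N2CC[C@@H](C)[C@@H](N(C)c3ncnc4[nH]ccc34)C2)n2nc(SCc3csc4ccc(Cl)cc34)nc2n1`: > 100000 nM (a limit)
- Compound 3 `Cc1cc(N2CC[C@@H](C)[C@@H](N(C)c3ncnc4[nH]ccc34)C2)n2nc(SCc3ccc(Br)cc3)nc2n1`: 55600 nM

All three compounds were tested in a toxicity assay on GES1 cells (Homo sapiens) for inhibition, read by MTT assay, with a stated time of 72 h (on this read-out higher numbers stand for weaker inhibition and lower numbers for stronger inhibition), a check of harm to ordinary cells. Compound 3 gives 55600 nM, which lies within the scatter of compound 1 at 40200 nM. Compound 2 reads > 100000 nM, and this is a limit of the assay, not a number.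

The next compound, compound 4 `C#CSc1nc2nc(C)cc(N3CC[C@@H](C)[C@@H](N(C)c4ncnc5[nH]ccc45)C3)n2n1`, changes the group on the sulfur: ethynyl in place of 4-bromobenzyl (ethynyl in place of 4-bromobenzyl on a sulfur). Going by the values given here, three measured steps bear on this, since each swaps a ring group on the chain carbon bound to that sulfur. They are a 1.4-fold higher number from compound 1 to compound 3 (0.14 log units; within the scatter), an at least 2.4-fold higher number from compound 1 to compound 2 (0.39 log units; beyond the scatter) and an at least 1.7-fold lower number from compound 2 to compound 3 (0.25 log units; that floor lies within the scatter). So only the step to compound 2 clearly exceeds the scatter, and it was modest. None of them replaces the whole group on the sulfur, so the evidence is indirect and the range must stay wide. With compound 3 as the starting point and a 1.4-fold higher number from compound 1 to compound 3 (0.14 log units; within the scatter) as the closest guide, no change beyond the scatter is expected, and the estimate is a 1.1-fold lower number from compound 3 to compound 4 (0.05 log units; within the scatter). For compound 4 the estimated value is 50000 nM, with an expected range from 18000 nM to 100000 nM.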

Compound 4, half-maximal inhibitory concentration: > 100000 nM
Compound 4 gave a limit, no number; the forecaster's own chance of this, stated with the estimate: 30%; middle value at least 2.0-fold (0.30 log units) away from the limit.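

In this assay compound 4 gives > 100000 nM, which is a limit of the assay and not a number. The earlier compounds shown here changed only the ring on the chain carbon, whereas here the whole 4-bromobenzyl group leaves the sulfur, ring included, and the much smaller ethynyl group gives no sign of stronger harm to these cells: the comparison with the bromine compound shows an at least 1.7-fold higher number from compound 3 to compound 4 (0.25 log units; that floor lies within the scatter), and the comparison with the benzimidazole compound shows an at least 2.4-fold higher number from compound 1 to compound 4 (0.39 log units; beyond the scatter). The step between compound 2 and compound 4 cannot be read, because both stand at the same limit: the limit of > 100000 nM in this assay, at which 2 of the 4 values shown sit.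

On these data alone, how far compound 4 lies past that limit stays unknown, and so does whether the result follows the loss of the ring or the arrival of the triple bond. A plain propyl chain on the sulfur, or a benzyl group carrying an amine or a carboxylic acid, would help to separate these two changes.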